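A few compounds are considered here, and "the series" means these few. Any claim that something is new, unique, unknown or untested is made for them only; others in the source may bear on it.

Measured so far:
- compound 1, `O=C(OCc1cccc(-c2ccccc2)c1)c1cccc(S)n1`: 50000 nM
- compound 2, `O=C(OCc1cccc(Oc2ccccc2)c1)c1cccc(S)n1`: 75000 nM
- compound 3, `Cc1ccc(COC(=O)c2cccc(=O)[nH]2)cc1`: 68000 nM

All three numbers come from an assay on isolated protein for inhibition of matrix metalloproteinase-9 (Homo sapiens) (on this read-out higher numbers stand for weaker inhibition and lower numbers for stronger inhibition), and all three sit close together. Compound 3 has the second highest of the three numbers; its nearest neighbour is compound 2, and its furthest is compound 1, but both gaps lie within the scatter, so none of the three can be called stronger or weaker than another.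

Compound 4 is `O=C(OCc1ccc(F)cc1)c1cccc(=O)[nH]1`. It differs from compound 3 in one place: fluoro in place of methyl on an aromatic carbon. Going by the values given here, the only step measured between single-change pairs is the one from compound 1 to compound 2, which is a 1.5-fold higher number from compound 1 to compound 2 (0.18 log units; within the scatter). That step swaps one group on an aromatic carbon for another, much as the step to compound 4 does, and it stays within the scatter. Among the compounds with values here, there is no measured pair that swaps methyl for fluoro, so the closest guide is this one small step and the narrow spread of all three numbers. On that basis no change beyond the scatter is expected in this assay.

Compound 4 is therefore expected to give about 70000 nM, a step of a 1.0-fold higher number from compound 3 to compound 4 (0.01 log units; within the scatter), with a range from 35000 nM to 140000 nM.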

Compound 4, half-maximal inhibitory concentration: 3000 nM
Compound 4: middle estimate off by 23-fold (1.37 log units), on the high side; measured number outside the range, below it.
By their numbers in this assay, from the lowest: compound 4; then compounds 1, 3 and 2 (each within the scatter of the next).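

Going by these compounds alone, the swap of methyl for fluoro on the aromatic carbon para to a large group gives a 23-fold lower number from compound 3 to compound 4 (1.36 log units; beyond the scatter) in this assay and is the only step in this set that goes beyond the scatter. This position is therefore sensitive: exchanging one heavy atom for another, with no ring, hydrogen-bond donor, hydrogen-bond acceptor or net charge gained or lost, is enough to separate compound 4 clearly from compound 3. Within the data shown here, the one earlier step, a 1.5-fold higher number from compound 1 to compound 2 (0.18 log units; within the scatter), stayed within the scatter and was a change of a different group, so it gave no sign that so small a substitution on an aromatic ring could matter this much. Nothing measured here explains the size of this step.

On these data alone, whether fluoro helps at this position or methyl hinders there stays open, as does how a plain hydrogen, chloro or methoxy at the same carbon would compare. Also open, as far as these compounds go, is whether the same swap would produce a step of similar size on the core of compound 1.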